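The source may hold more compounds than are shown below. What is called first, only, known or untested is meant among the compounds shown, and "the series" means these compounds.

Compound 1 (`Nc1ncnc2c1ncn2[C@@H]1S[C@H](CO)C=C1F`) was read in an ADME assay on cells (Homo sapiens) for cytotoxicity (on this read-out lower numbers stand for stronger inhibition and higher numbers for weaker inhibition), and gives > 100000 nM as a limit of the assay, not a number. Compound 2 (`Nc1nc2c(ncn2[C@@H]2S[C@H](CO)C=C2F)c(=O)[nH]1`) gives > 100000 nM as a limit too. Both compounds sit together (the limit of > 100000 nM in this assay, at which 2 of the 2 values shown sit) and no order can be drawn between them, so compound 1 has no exact position in the series.

Compound 3 (`Nc1nc(F)nc2c1ncn2[C@@H]1S[C@H](CO)C=C1F`) has no reading yet. It carries fluoro in place of hydrogen on an aromatic carbon of the core of compound 1, between two ring nitrogen atoms (fluoro in place of hydrogen on an aromatic carbon). Within the data shown here, no measured step shows what such a change does, so the expectation starts only from compound 1 and its limit (> 100000 nM). A small move toward stronger inhibition is expected, and the estimated change (an at least 1.2-fold lower number from compound 1 to compound 3 (0.09 log units; that floor lies within the scatter)) may not clear the usual scatter. Another reading at the limit remains quite possible. In this assay compound 3 is expected at 80000 nM (estimated range 20000 nM to 150000 nM).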

Compound 3, half-maximal inhibitory concentration: 1500 nM
For compound 3 the middle estimate is 53-fold (1.73 log units) above the measured one; the whole stated range lies above it.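

In this assay, fluoro in place of hydrogen on an aromatic carbon, between two ring nitrogen atoms, gives an at least 66-fold lower number from compound 1 to compound 3 (1.82 log units; beyond the scatter), which shows that this position of the core of compound 1 is not silent in this read-out and that a single heavy atom placed there is enough for a large step. Going by these compounds, compound 1 gives > 100000 nM, which is a limit of the assay and not a number, so the true size of the step is unknown and only its floor can be read. Compound 3 is the first compound in the series with an exact value, and so the first to stand clear of the ceiling that held the earlier readings: the limit of > 100000 nM in this assay, at which 2 of the 3 values shown sit.

On these data alone, whether the step belongs to fluoro itself or to any replacement of hydrogen at this carbon stays open, and chloro, methyl or an amine at the same position would help separate those cases. Among these compounds, also open is whether the step carries over to other compounds, since only this one pair shows the change and it gives no cause for the step.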